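Replacing the bromine on the chain of compound 2

The source may report more compounds than this note shows. Statements on the series, on what has been measured and on what is new or still open speak of the compounds shown alone.

In a functional assay on HeLa cells (Homo sapiens) for antiproliferative activity, read by MTT assay, with a stated time of 48 h (a lower number here means a stronger inhibitor, a higher number a weaker inhibitor), compound 1 (`COc1ccc(N(C)c2ccnc(Cl)n2)cc1[N+](=O)[O-]`) gives 4730 nM and compound 2 (`COc1ccc(N(C)c2ccnc(Cl)n2)cc1OCCBr`) gives 3310 nM. These values lie within the scatter of each other, so compound 2 has no clear rank. Compound 3 (`COc1ccc(N(C)c2ccnc(Cl)n2)cc1OCCC[Se]C#N`) carries a group of 4 heavy atoms (2 carbon, 1 nitrogen, 1 selenium; no ring) in place of one bromine atom, on a saturated chain carbon, two bonds along the chain from an oxygen on an aromatic ring. For the measured compounds named here, the only measured step, a 1.4-fold lower number from compound 1 to compound 2 (0.16 log units; within the scatter), concerns another change and offers weak guidance, and no measured compound contains selenium. A moderate step to a lower number is tentatively expected in this assay, with wide uncertainty. The expected step is a 2.5-fold lower number from compound 2 to compound 3 (0.41 log units; beyond the scatter). For compound 3, the estimate is 1300 nM, with an expected range of 300 nM to 4500 nM.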

Compound 3, half-maximal inhibitory concentration: 4710 nM
Beside the measured number, compound 3's estimate is 3.6-fold (0.56 log units) below it; the measured number lies above the stated range.
By their numbers in this assay, from the lowest: compounds 2, 3 and 1 (each within the scatter of the next).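

In this assay the group of 4 heavy atoms with selenium replaces bromine on the saturated chain carbon with no separation from the bromo compound (a 1.4-fold higher number from compound 2 to compound 3 (0.15 log units; within the scatter)). The same holds against the nitro-bearing compound (a 1.0-fold lower number from compound 1 to compound 3 (0.00 log units; within the scatter)), so all three compounds remain unranked and neither change on this series yet gives a readable gain or loss. Nothing at hand bears on why the selenium group gives this result.

Going by these compounds, whether an amine or a carboxylic acid on the same chain would separate from these compounds remains open. A longer chain carrying the same selenium group is equally unresolved.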